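The source may report more compounds than this note shows. Statements on the series, on what has been measured and on what is new or still open speak of the compounds shown alone.

Compound 1 `Cc1cccc(N2CCN(c3nc(C(F)(F)F)ccc3CNC(=O)C(C)c3ccc(NS(C)(=O)=O)c(F)c3)CC2)c1` gives 3.4 nM in a functional assay on CHO-K1 cells for antagonist activity at transient receptor potential cation channel subfamily V member 1 (Homo sapiens), read by FLIPR; a higher number here means a weaker inhibitor, a lower number a stronger inhibitor.
Compound 2 `CC(C(=O)NCc1ccc(C(F)(F)F)nc1N1CCN(c2ccc(C(F)(F)F)cc2)CC1)c1ccc(NS(C)(=O)=O)c(F)c1` gives 2.3 nM in this assay.

Among the two measured compounds, compound 2 has the lowest number in this assay, with compound 1 as its nearest neighbour; the step between them, a 1.5-fold lower number from compound 1 to compound 2 (0.17 log units; within the scatter), stays within the usual scatter, so the two cannot be told apart. That step exchanged one aromatic group for another on the ring nitrogen and left the number essentially unchanged.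

Compound 3 `CC(C(=O)NCc1ccc(C(F)(F)F)nc1N1CCN(c2ncccc2Cl)CC1)c1ccc(NS(C)(=O)=O)c(F)c1` is made from compound 2 by 3-chloropyridin-2-yl in place of 4-(trifluoromethyl)phenyl on an amine nitrogen in a ring. Among the measured compounds shown here, the change sits in the same position as the one measured step, and that step, a 1.5-fold lower number from compound 1 to compound 2 (0.17 log units; within the scatter), was too small to count. On that basis no step beyond the scatter is expected in this assay from compound 2 to compound 3, though a single measured step is a thin basis, and a ring with a hetero atom has not been tried at this position.

Compound 3 is therefore expected to give about 3 nM in this assay, within a range from 1 nM to 10 nM, which corresponds to an expected step of a 1.3-fold higher number from compound 2 to compound 3 (0.12 log units; within the scatter).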

Compound 3, inhibition constant: 2.1 nM
Compound 3: middle estimate off by 1.4-fold (0.15 log units), on the high side; measured number inside the range.
By their numbers in this assay, from the lowest: compounds 3, 2 and 1 (each within the scatter of the next).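

The ring on the amine nitrogen can now carry a hetero atom: 3-chloropyridin-2-yl has fewer heavy atoms than 4-(trifluoromethyl)phenyl and brings a hydrogen-bond acceptor, yet this assay shows only a small step (a 1.1-fold lower number from compound 2 to compound 3 (0.04 log units; within the scatter)), which stays within the scatter. Against the 3-methylphenyl group the same replacement also stays within the scatter (a 1.6-fold lower number from compound 1 to compound 3 (0.21 log units; within the scatter)), so all three aromatic groups at this position give numbers that cannot be told apart, whether the ring holds only carbon or also a nitrogen, and whether its substituent is methyl, trifluoromethyl or chlorine. No measurement is available that would explain why these different groups give such similar numbers.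

All three compounds keep an aromatic ring on this nitrogen and share the rest of the structure, so the result says nothing about groups of another kind. Going by these compounds, it remains open whether a saturated ring such as cyclohexyl, a plain alkyl chain, or an aromatic ring bearing a carboxylic acid or an amine would keep the number in the same range.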